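The source may hold more compounds than are shown below. What is called first, only, known or untested is meant among the compounds shown, and "the series" means these compounds.

Compound 1 `NC(CO[C@@H]1O[C@H](CO)[C@H](O)[C@H](O)[C@H]1O)C(=O)NCCCCCCCCCCCC(=O)O`: > 100000 nM, a limit
Compound 2 `O=C(O)CCCCCCCCCCCNC(=O)C(CO[C@@H]1O[C@H](CO)[C@H](O)[C@H](O)[C@H]1O)NC(=O)CCC(=O)O`: > 100000 nM, a limit

In a functional assay on CEM-SS cells (Homo sapiens) for cytotoxicity (on this read-out higher numbers stand for lower toxicity in this test and lower numbers for higher toxicity in this test), compound 2 gives only the limit > 100000 nM and no number. Both compounds share this position: the limit of > 100000 nM in this assay, at which 2 of the 2 values shown sit.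

Compound 3 `CCCCCCCCCCCCCCNC(=O)C(CO[C@@H]1O[C@H](CO)[C@H](O)[C@H](O)[C@H]1O)NC(=O)CCC(=O)O` differs from compound 2 at the chain end: propyl in place of carboxy on a saturated chain carbon, ten or more bonds along the chain from an amide-type nitrogen.

Among the measured compounds shown here, the one measured step, a step that the two limits leave unreadable from compound 1 to compound 2, has no size to carry over, so the expectation is loose: a modest move towards lower numbers in this assay, or none visible at the limit. The expected step is an at least 2.0-fold lower number from compound 2 to compound 3 (0.30 log units; that floor lies within the scatter). For compound 3 the estimated value is 50000 nM, with an expected range of 15000 nM to 100000 nM.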

Compound 3, half-maximal cytotoxic concentration: > 100000 nM
Compound 3: no number, only a limit (the forecaster's own chance of this, stated with the estimate: 50%); middle value at least 2.0-fold (0.30 log units) away from the limit.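

Among the compounds shown here, compound 2 and compound 3 both give only a limit in this assay, so no step between them can be read. The compounds shown leave open what size, if any, the change from carboxy to propyl has in this assay.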